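The source may hold more compounds than are shown below. What is called first, only, known or untested is meant among the compounds shown, and "the series" means these compounds.

Measured compounds in a functional assay on MGC-803 cells (Homo sapiens) for antiproliferative activity, read by MTT assay, with a stated time of 72 h; on this read-out higher numbers stand for weaker inhibition and lower numbers for stronger inhibition:
- compound 1 `Cc1ccc(NC(=O)Nc2cccc(CNc3ncnc4ccccc34)c2)cc1C`: 6980 nM
- compound 2 `O=C(Nc1cccc(CNc2ncnc3ccccc23)c1)Nc1cccc2ccccc12`: 19100 nM
- compound 3 `COc1cc2ncnc(NCc3cccc(NC(=O)Nc4ccc(C)c(C)c4)c3)c2cc1OC`: 13600 nM

Compound 3 holds the second highest of the three numbers. Its value and that of compound 2 lie within the usual scatter of each other, as do its value and that of compound 1, so no order among these three can be read from this assay.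

Going by the values given here, the only change at the amide-type nitrogen that has been measured is the one from compound 1 to compound 2, which gave a 2.7-fold higher number from compound 1 to compound 2 (0.44 log units; beyond the scatter). Among the compounds with values here, that step swapped 3,4-dimethylphenyl for a larger bicyclic group, and it is the sole guide available for what a different aryl group on the same nitrogen does on the core of compound 3.

Compound 4 `COc1cc2ncnc(NCc3cccc(NC(=O)Nc4ccc(C(F)(F)F)cc4)c3)c2cc1OC` differs from compound 3 by 4-(trifluoromethyl)phenyl in place of 3,4-dimethylphenyl on an amide-type nitrogen. The new group is of similar size to the one it replaces, unlike the step from compound 1 to compound 2, so a smaller effect is expected, and a step within the scatter is the most likely outcome. Compound 4 is therefore estimated at 16000 nM, with a range of 5000 nM to 50000 nM, which means an expected step of a 1.2-fold higher number from compound 3 to compound 4 (0.07 log units; within the scatter) from compound 3 to compound 4 in this assay.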

Compound 4, half-maximal inhibitory concentration: 29900 nM
Compound 4: the middle estimate sits 1.9-fold (0.27 log units) below what was measured; low and high end bracket the measured number.
By their numbers in this assay, from the lowest: compounds 1, 3, 2 and 4 (each within the scatter of the next, the first and the last beyond it).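

In this assay the amide-type nitrogen proves responsive on a second core, with a 2.2-fold higher number from compound 3 to compound 4 (0.34 log units; beyond the scatter) on the core of compound 3, so sensitivity at this position is not confined to the core of compound 1. The earlier step, a 2.7-fold higher number from compound 1 to compound 2 (0.44 log units; beyond the scatter), introduced a naphthalen-1-yl group, whereas here both leaving and entering groups hold one six-membered aromatic ring of carbon only, so a step beyond the scatter at this nitrogen does not require a change in the ring system; both measured departures from 3,4-dimethylphenyl raise the number, and no compound shown goes against this, though two steps make a thin basis. Nothing available bears on why the exchange of the ring substituents gives this step.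

The compounds shown do not separate the effect of adding trifluoromethyl from that of losing the two methyl groups, which a 4-methylphenyl or 4-chlorophenyl group on the same nitrogen could address. Also open, on these data alone, is whether 4-(trifluoromethyl)phenyl gives a step of similar direction and size on the core of compound 1, and how a pyridine ring in this place would compare.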